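Changing the group on the amine nitrogen

The compounds below may be only part of what the source reports. "The series", "measured", "known", "first", "only" and "open" are said of these compounds alone.

Compound 1 `COc1ccc(N/C=C\C(=O)c2nc(-c3ccc(F)cc3)n3ccccc23)cc1`: 2560 nM in a functional assay on B16-F10 cells (Mus musculus) for cytotoxicity, read by MTT assay, with a stated time of 48 h; on this read-out lower numbers stand for stronger inhibition and higher numbers for weaker inhibition
Compound 2 `COc1ccc(N/C=C\C(=O)c2nc(-c3ccccc3)n3ccccc23)cc1`: 1790 nM
Compound 3 `Cc1cc2cc(N/C=C\C(=O)c3nc(-c4ccc(F)cc4)n4ccccc34)ccc2[nH]1`: not yet measured

Compound 1 gives the higher of the two numbers shown, but its gap to compound 2, hydrogen in place of fluoro on an aromatic carbon, is a step of a 1.4-fold lower number from compound 1 to compound 2 (0.16 log units; within the scatter) and so within the scatter. Compound 3 alters a different part: 2-methyl-1H-indol-5-yl in place of 4-methoxyphenyl on an amine nitrogen. For the measured compounds named here, no measured step touches the amine nitrogen, so the single step on record bears on it only indirectly. The expected step of a 1.3-fold lower number from compound 1 to compound 3 (0.11 log units; within the scatter) is therefore small, with wide uncertainty. Compound 3 is estimated at 2000 nM, between 600 nM and 7000 nM.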

Compound 3, half-maximal inhibitory concentration: > 30000 nM
Compound 3: only a limit was reported; the forecaster's own chance of this, stated with the estimate: 5%; middle value at least 15-fold (1.17 log units) away from the limit.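

For the compounds shown here, the amine nitrogen proves sensitive to what it carries: 2-methyl-1H-indol-5-yl in place of 4-methoxyphenyl gives an at least 11-fold higher number from compound 1 to compound 3 (1.06 log units; beyond the scatter), whereas the only earlier step, at the aromatic fluoro, stayed within the scatter. The value for compound 3 is a limit, not a number: the limit of > 30000 nM in this assay, at which 1 of the 3 values shown sits.

Only one replacement on this nitrogen is shown, so the compounds cannot separate the part played by the methyl from that of the 2-methyl-1H-indol-5-yl group as a whole. Going by these compounds, it remains open whether a plain phenyl or an unmethylated 1H-indol-5-yl there would give numbers nearer to compound 1.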